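Methyl-to-chloro step in a three-compound series, one estimate

A few compounds are considered here, and "the series" means these few. Any claim that something is new, unique, unknown or untested is made for them only; others in the source may bear on it.

Values in a functional assay on MOLT-4 cells (Homo sapiens), with a stated time of 72 h; on this read-out lower numbers stand for stronger inhibition and higher numbers for weaker inhibition:
compound 1 `Cc1ccc(NC(=S)N/N=C2\C(=O)Nc3ccc(F)cc32)cc1` gives 3000 nM
compound 2 `O=C1Nc2ccc(F)cc2/C1=N/NC(=S)Nc1ccc(Cl)cc1` gives 14000 nM
compound 3 `Cc1ccc(NC(=S)N/N=C2\C(=O)N(Cc3ccc(Cl)cc3)c3ccc(Br)cc32)cc1` gives 288000 nM

Going by the values given here, the one counted change among the measured compounds is chloro in place of methyl on an aromatic carbon, and it gave a 4.7-fold higher number from compound 1 to compound 2 (0.67 log units; beyond the scatter). Compound 3 carries a different core; the difference between the two cores is not broken down here, and compound 3 stands with the highest number of the three in this assay.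

Compound 4 `O=C1/C(=N\NC(=S)Nc2ccc(Cl)cc2)c2cc(Br)ccc2N1Cc1ccc(Cl)cc1` differs from compound 3 by chloro in place of methyl on an aromatic carbon, the same change at the same kind of place as between compound 1 and compound 2. A step of similar size is expected, resting on a 4.7-fold higher number from compound 1 to compound 2 (0.67 log units; beyond the scatter), so for compound 4 the expected step is a 3.1-fold higher number from compound 3 to compound 4 (0.49 log units; beyond the scatter). The estimate for compound 4 in this assay is 900000 nM, with a range from 250000 nM to 3000000 nM.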

Compound 4, half-maximal inhibitory concentration: 280000 nM
For compound 4 the middle estimate is 3.2-fold (0.51 log units) above the measured one; low and high end bracket the measured number.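

In this assay, chloro in place of methyl gave a 1.0-fold lower number from compound 3 to compound 4 (0.01 log units; within the scatter), so on the core of compound 3 this change shows no step beyond the scatter. The change did not carry over in size from one core to the other: the same change on two cores in this assay, a 4.7-fold higher number (0.67 log units; beyond the scatter) from compound 1 to compound 2 and a 1.0-fold lower number (0.01 log units; within the scatter) from compound 3 to compound 4, 4.8-fold (0.68 log units) apart, beyond the scatter of two such steps. This rests on one pair per core, and the cores differ in more than one place, so the part of that difference that matters cannot be read from these compounds, nor can any general rule for the series.

Still open, from the compounds shown here alone, is whether the same gap between cores would appear with another group at this place, such as an amine or a carboxylic acid in place of methyl. Also open, going by these compounds, is how either core would respond to a methoxy group there.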